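The source may report more compounds than this note shows. Statements on the series, on what has been measured and on what is new or still open speak of the compounds shown alone.

Of the compounds shown here, three built on one shared core have been measured in a functional assay on HT-29 cells (Homo sapiens) for inhibition, read by luminescence and CellTiter-Glo, with a stated time of 24 h; a lower number here means that less compound is needed, a higher number that more compound is needed for the effect. Compound 1 `CCCCCn1nc(C(=O)N[C@H]2COc3ccccc3N(C)C2=S)nc1Cc1ccccc1` gives 805 nM. Compound 2 `COCCn1nc(C(=O)N[C@H]2COc3ccccc3N(C)C2=S)nc1Cc1ccccc1` gives 566 nM, the lowest number of the three, although the step of a 1.4-fold lower number from compound 1 to compound 2 (0.15 log units; within the scatter) stays within the scatter, so compound 1 and compound 2 cannot really be told apart. Compound 3 `CN1C(=S)[C@@H](NC(=O)c2nc(Cc3ccccc3)n(CC3COC3)n2)COc2ccccc21` gives 2830 nM; the steps of a 3.5-fold higher number from compound 1 to compound 3 (0.55 log units; beyond the scatter) and a 5.0-fold higher number from compound 2 to compound 3 (0.70 log units; beyond the scatter) both go beyond the scatter, so compound 3 stands furthest from compound 2.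

Compound 4 `CN1C(=S)[C@@H](NC(=O)c2nc(Cc3ccccc3)n(C3CCNC3)n2)COc2ccccc21` has not yet been measured. It differs from compound 2 by pyrrolidin-3-yl in place of 2-methoxyethyl on an aromatic nitrogen. The measured steps that bear on this are the two leading to compound 3, where a ring bound to the aromatic nitrogen took the place of an open chain and the numbers rose: a 5.0-fold higher number from compound 2 to compound 3 (0.70 log units; beyond the scatter) and a 3.5-fold higher number from compound 1 to compound 3 (0.55 log units; beyond the scatter). Compound 4 also carries a ring bound to that aromatic nitrogen, a pyrrolidin-3-yl rather than an oxetan-3-yl. A modest rise in the number is therefore expected, on the order of a 3.5-fold higher number from compound 2 to compound 4 (0.55 log units; beyond the scatter). For compound 4 the estimated value in this assay is 2000 nM, with a range from 800 nM to 5000 nM.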

Compound 4, half-maximal effective concentration: 1070 nM
For compound 4 the middle estimate is 1.9-fold (0.27 log units) above the measured one, within the range that was stated.
By their numbers in this assay, from the lowest: compounds 2, 1 and 4 (each within the scatter of the next); then compound 3.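

In this assay the position on the aromatic nitrogen accepts a ring without a clear change from the open chains: the result a 1.9-fold higher number from compound 2 to compound 4 (0.28 log units; within the scatter) stays within the scatter, and so does the result a 1.3-fold higher number from compound 1 to compound 4 (0.12 log units; within the scatter) when pentyl is the chain replaced. A ring as such therefore does not account for the higher number of compound 3, and the ring-bearing groups differ from each other, as a 2.6-fold lower number from compound 3 to compound 4 (0.42 log units; beyond the scatter) shows with a step beyond the scatter, although pyrrolidin-3-yl and (oxetan-3-yl)methyl differ both in the ring and in how it is attached. Nothing available explains why these two groups part ways.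

A cyclopentyl group, with carbon in place of the ring nitrogen, or an N-methylpyrrolidin-3-yl group would show whether that nitrogen and its hydrogen matter at this position. An oxetan-3-yl group set directly on the aromatic nitrogen, or a (pyrrolidin-3-yl)methyl group, would separate the effect of the ring from that of its attachment.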